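Acetyl for Methoxy on a Trifluoromethyl Core: Expected Cytotoxicity

This account rests on a few compounds, and the source may have more. Where it says the series, first, only, none or still open, it means among the compounds named here.

Measured compounds:
Compound 1, `CC(=O)c1ccc(N2CCN(C(=O)c3nc4cc(Cl)ccc4s3)CC2)cc1`, 30.8%
Compound 2, `COc1ccc(N2CCN(C(=O)c3nc4cc(Cl)ccc4s3)CC2)cc1`, 42.8%
Compound 3, `COc1ccc(N2CCN(C(=O)c3nc4cc(C(F)(F)F)ccc4s3)CC2)cc1`, 19.4%

The three measured compounds were tested in an ADME assay on RAW264.7 cells (Mus musculus) for cytotoxicity, read by MTT assay, with a stated time of 72 h, tested at 50 ug/mL; on this read-out lower numbers stand for less inhibition and higher numbers for more inhibition at the one concentration tested (going by the name of the read-out). Compound 2 gives 42.8%, the highest of the three numbers. Two single changes start from compound 2. The first, (acetyl in place of methoxy on an aromatic carbon), gives compound 1 with 30.8%, a step of a number 12 percentage points lower from compound 2 to compound 1 (beyond the scatter). The second, (trifluoromethyl in place of chloro on an aromatic carbon), changes the core and gives compound 3 with 19.4%, a step of a number 23.4 percentage points lower from compound 2 to compound 3 (beyond the scatter); compound 3 stands lowest of the three, beyond the scatter from both others.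

Compound 4, `CC(=O)c1ccc(N2CCN(C(=O)c3nc4cc(C(F)(F)F)ccc4s3)CC2)cc1`, is not yet measured. It differs from compound 3 by acetyl in place of methoxy on an aromatic carbon, the same change as from compound 2 to compound 1, made here on the core of compound 3. From compound 3 to compound 4 a step of about a number 9.4 percentage points lower from compound 3 to compound 4 (within the scatter) is expected, resting on the earlier step of a number 12 percentage points lower from compound 2 to compound 1 (beyond the scatter) and on the fact that compound 3 already starts low, leaving less room to fall. Compound 4 is therefore estimated at 10%, between 0% and 24%.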

Compound 4, a percentage reported as inhibition, at one concentration (the size of the read-out at that concentration, not a potency): 30.6%
Estimate against measurement, compound 4: 20.6 percentage points below, outside the stated range (above it).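

In this assay, acetyl in place of methoxy on the trifluoromethyl-bearing core gives a number 11.2 percentage points higher from compound 3 to compound 4 (beyond the scatter), so the change does not carry over from the other core in direction or size: the same change on two cores in this assay, a number 12 percentage points lower (beyond the scatter) from compound 2 to compound 1 and a number 11.2 percentage points higher (beyond the scatter) from compound 3 to compound 4, 23.2 percentage points apart, beyond the scatter of two such steps. Likewise, with the acetyl group present, trifluoromethyl in place of chloro gives a number 0.2 percentage points lower from compound 1 to compound 4 (within the scatter), whereas with the methoxy group present the same change lowered the number: the same change on two cores in this assay, a number 23.4 percentage points lower (beyond the scatter) from compound 2 to compound 3 and a number 0.2 percentage points lower (within the scatter) from compound 1 to compound 4, 23.2 percentage points apart, beyond the scatter of two such steps. The four compounds thus show that, in this set, the effect of each change depends on the group at the other place, but they do not show why, and a single pair for each core cannot predict how either change would behave on a further core.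

As far as these compounds go, how an amine or a carboxylic acid in place of acetyl or methoxy on that aromatic carbon would read on these two cores remains open. From the compounds shown here alone, whether a nitrile in place of chloro or trifluoromethyl would follow either result also remains open.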